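Swapping one side chain on a weakly cytotoxic core

The source may hold more compounds than are shown below. What is called first, only, known or untested is meant among the compounds shown, and "the series" means these compounds.

In a functional assay on HeLa cells (Homo sapiens) for cytotoxicity, read by MTT assay (a higher number here means a weaker inhibitor, a lower number a stronger inhibitor), compound 1 `CCCC(CC(=O)O[C@H](CC=C(C)C)C1=CC(=O)c2c(O)ccc(O)c2C1=O)OC(C)=O` gives 51200 nM and compound 2 `CCC(CO[C@H](CC=C(C)C)C1=CC(=O)c2c(O)ccc(O)c2C1=O)OC(C)=O` gives 44000 nM, so the two values lie within the usual scatter of each other. Compound 3 `CC(C)=CC[C@@H](OC(=O)CC(C)(O)C(C)C)C1=CC(=O)c2c(O)ccc(O)c2C1=O` has not yet been measured. It differs from compound 2 by carrying (2-hydroxy-2,3-dimethylbutyl)carbonyl in place of 2-acetoxybutyl on an oxygen on a saturated carbon. Among the compounds with values here, no measured pair shows this change, so no direction can be favoured. The expected size is small, and the estimated step, a 1.1-fold lower number from compound 2 to compound 3 (0.04 log units; within the scatter), stays within the scatter. For compound 3 the expected value is 40000 nM, with an estimated range from 14000 nM to 90000 nM.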

Compound 3, half-maximal inhibitory concentration: 27700 nM
The estimate for compound 3 lay 1.4-fold (0.16 log units) above the measured number, within the range that was stated.
By their numbers in this assay, from the lowest: compounds 3, 2 and 1 (each within the scatter of the next).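

In this assay the side chain on an oxygen on a saturated carbon can be exchanged for a differently built one without leaving the scatter. Placing (2-hydroxy-2,3-dimethylbutyl)carbonyl, which carries a hydrogen-bond donor, in place of 2-acetoxybutyl gives a 1.6-fold lower number from compound 2 to compound 3 (0.20 log units; within the scatter) and replacing 1-acetoxybutyl with 1-hydroxy-1,2-dimethylpropyl gives a 1.8-fold lower number from compound 1 to compound 3 (0.27 log units; within the scatter), so neither exchange separates the compounds. No measurement is available to explain these results. As far as these compounds go, whether a side chain ending in an amine or a carboxylic acid would move the number beyond the scatter remains open.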